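This account rests on a few compounds, and the source may have more. Where it says the series, first, only, none or still open, it means among the compounds named here.

Compound 1 `COc1cc(-c2cc(/C=C/C(=O)c3ccc(N)cc3)[nH]n2)cc(OC)c1OC` and compound 2 `COc1ccc(-c2cc(/C=C/C(=O)c3ccc(N)cc3)[nH]n2)cc1OC` share a core and differ in one place. In a functional assay on DU-145 cells (Homo sapiens) for inhibition, read by sulforhodamine B assay, with a stated time of 48 h (a higher number here means a weaker inhibitor of growth, a lower number a stronger inhibitor of growth), compound 1 gives 1650 nM. In this assay compound 2 gives 3740 nM. The change from compound 1 to compound 2 is hydrogen in place of methoxy on an aromatic carbon, and it made a step of a 2.3-fold higher number from compound 1 to compound 2 (0.36 log units; beyond the scatter).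

Compound 3 `COc1cc(C(=O)/C=C/c2cc(-c3cc(OC)c(OC)c(OC)c3)n[nH]2)cc(OC)c1OC` belongs to a different core, and the difference between the two cores is not broken down here. In this assay compound 3 gives "not determined" (no result reported), so no number stands beside it.

Compound 4 `COc1ccc(-c2cc(/C=C/C(=O)c3cc(OC)c(OC)c(OC)c3)[nH]n2)cc1OC` is derived from compound 3 by the same change, (hydrogen in place of methoxy on an aromatic carbon), with the surroundings of the place worded identically in both cases. It has not yet been measured in this assay. Going by the values given here, what can be expected rests on the single earlier step, a 2.3-fold higher number from compound 1 to compound 2 (0.36 log units; beyond the scatter), which was modest and lay beyond the scatter, pointing to a somewhat higher number. Since compound 3 has no measured value, there is no starting point for the step on the second core, and the expectation for compound 4 draws only on the range in which compound 1 and compound 2 fall and on the direction of that earlier step. On that basis compound 4 is estimated at 3000 nM in this assay, with a likely span from 700 nM to 13000 nM.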

Compound 4, concentration for 50% growth inhibition: 1830 nM
The estimate for compound 4 lay 1.6-fold (0.21 log units) above the measured number; low and high end bracket the measured number.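

Compound 3 has no reported number in this assay, so the step from compound 3 to compound 4 cannot be read, and compound 4 at 1830 nM has no partner on its core. As far as these compounds go, whether hydrogen in place of methoxy acts on this core as it did in a 2.3-fold higher number from compound 1 to compound 2 (0.36 log units; beyond the scatter) stays open. Nothing shown here offers an explanation for these values.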